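From Phenyl to 4-Chlorophenyl in Compound 3

The source may hold more compounds than are shown below. What is called first, only, known or untested is meant among the compounds shown, and "the series" means these compounds.

In a functional assay on NCI-H23 cells (Homo sapiens) for inhibition, with a stated time of 48 h (on this read-out higher numbers stand for weaker inhibition of growth and lower numbers for stronger inhibition of growth), compound 1 (`COc1ccccc1/C=C/C(=O)c1c(O)cc2occc2c1OC`) gives 22400 nM, and compound 2 (`COc1c(C(=O)/C=C/c2ccc(Cl)cc2)c(O)c(Br)c2occc12`) gives 3250 nM. Compound 3 (`C=CCc1c(O)c(C(=O)/C=C/c2ccccc2)c(OC)c2ccoc12`) gives 2520 nM. That places compound 3 level with compound 2, within the usual scatter of repeated measurements, and clearly below compound 1, which means stronger inhibition of growth than compound 1 shows.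

Compound 4 (`C=CCc1c(O)c(C(=O)/C=C/c2ccc(Cl)cc2)c(OC)c2ccoc12`) has not yet been measured. It differs from compound 3 in one place: chloro in place of hydrogen on an aromatic carbon. This is chloro in place of hydrogen on an aromatic carbon, para to a large group, so phenyl becomes 4-chlorophenyl.

Within the data shown here, no two measured compounds differ in only one place, so the size of this change has not been seen directly. Compound 2 also carries a 4-chlorophenyl and gives 3250 nM, but it differs from compound 3 elsewhere too, so it offers only a weak hint. No step beyond the scatter is expected, and the estimated step is a 1.1-fold lower number from compound 3 to compound 4 (0.06 log units; within the scatter). The estimated value for compound 4 is 2200 nM, with an expected range from 1000 nM to 5000 nM.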

Compound 4, concentration for 50% growth inhibition: 2780 nM
Compound 4: the middle estimate sits 1.3-fold (0.10 log units) below what was measured, within the range that was stated.
By their numbers in this assay, from the lowest: compounds 3, 4 and 2 (each within the scatter of the next); then compound 1.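

In this assay, placing chloro on this aromatic carbon, para to a large group, so that phenyl becomes 4-chlorophenyl, gives a 1.1-fold higher number from compound 3 to compound 4 (0.04 log units; within the scatter) and leaves the two compounds level on this read-out. A second single-place comparison now exists as well: allyl in place of bromo on an aromatic carbon gives a 1.2-fold lower number from compound 2 to compound 4 (0.07 log units; within the scatter) and is also within the scatter, so with 4-chlorophenyl present these two groups cannot be told apart here. No other measurement is available that would explain either result.

From the compounds shown here alone, the chloro comparison rests on a single pair, so it remains open how a methoxy group or an amine would read at the same place. Going by these compounds, it is also open whether a longer chain in place of allyl would stay level with compound 4.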